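Methoxy added to the chloro-substituted ring of compound 2

The source may hold more compounds than are shown below. What is called first, only, known or untested is meant among the compounds shown, and "the series" means these compounds.

In an ADME assay on Huh7.5.1 cells (Homo sapiens) for cytotoxicity, read by ATP content, with a stated time of 48 h (a lower number here means that less compound is tolerated, a higher number that more compound is tolerated), compound 2 `Cc1oc(-c2ccccc2Cl)nc1CN1CCC(C(=O)NCCCN2C[C@H](C)C[C@H](C)C2)CC1` gives 16500 nM, the higher of the two numbers seen, while compound 1 `Cc1ccccc1-c1nc(CN2CCC(C(=O)NCCCN3CC(C)(C)CC(C)(C)C3)CC2)c(C)o1` gives 4380 nM. Compound 3 `COc1cccc(Cl)c1-c1nc(CN2CCC(C(=O)NCCCN3C[C@H](C)C[C@H](C)C3)CC2)c(C)o1` has not been measured; it differs from compound 2 by methoxy in place of hydrogen on an aromatic carbon. For the measured compounds named here, no step between measured compounds bears on this change, so the account rests on compound 2 alone. A step of no more than the usual scatter, in either direction, is expected for a 1.1-fold lower number from compound 2 to compound 3 (0.04 log units; within the scatter). Compound 3 is therefore estimated at 15000 nM, within a range from 6000 nM to 40000 nM.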

Compound 3, half-maximal cytotoxic concentration: 15800 nM
The estimate for compound 3 lay 1.1-fold (0.02 log units) below the measured number; the range from low to high includes it.
By their numbers in this assay, from the lowest: compound 1; then compounds 3 and 2 (each within the scatter of the next).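

Methoxy in place of hydrogen on this aromatic carbon, which turns 2-chlorophenyl into 2-chloro-6-methoxyphenyl, is the first single change that can be read here, and in this assay it gives a 1.0-fold lower number from compound 2 to compound 3 (0.02 log units; within the scatter). This carbon, ortho to a large group and meta to a chloro group, therefore takes methoxy without a change beyond the scatter in this read-out. Nothing measured here bears on why this is so.

Going by these compounds, whether ethoxy, an amine or a carboxylic acid on the same carbon would behave alike remains open. So does whether methoxy would give the same result in a compound with methyl in place of chloro.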